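From 2-chlorophenyl to 2,5-dichlorophenyl at the assay limit

This account rests on a few compounds, and the source may have more. Where it says the series, first, only, none or still open, it means among the compounds named here.

Values so far in an ADME assay on Karpas-1106P cells (Homo sapiens) for cytotoxicity (a lower number here means that less compound is needed, a higher number that more compound is needed for the effect), for three compounds:
- Compound 1 `Cc1ccc(S(=O)(=O)N[C@@H](CC(=O)NC(C)(C)C)C(=O)NCCNC(=O)c2ccccc2)cc1` gives > 11100 nM as a limit
- Compound 2 `Cc1ccc(S(=O)(=O)N[C@@H](CC(=O)NC(C)(C)C)C(=O)NCCNC(=O)c2c(O)cccc2F)cc1` gives > 11100 nM as a limit
- Compound 3 `Cc1ccc(S(=O)(=O)N[C@@H](CC(=O)NC(C)(C)C)C(=O)NCCNC(=O)c2ccccc2Cl)cc1` gives > 11100 nM as a limit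

Compound 3 reads > 11100 nM and this is a limit, not a number. All three measured compounds rest on the limit of > 11100 nM in this assay, at which 3 of the 3 values shown sit, and so cannot be ranked against one another.

Compound 4 `Cc1ccc(S(=O)(=O)N[C@@H](CC(=O)NC(C)(C)C)C(=O)NCCNC(=O)c2cc(Cl)ccc2Cl)cc1` differs from compound 3 by chloro in place of hydrogen on an aromatic carbon, which turns 2-chlorophenyl into 2,5-dichlorophenyl. The counted difference is chloro in place of hydrogen on an aromatic carbon and nothing else in the structure changes.

The same kind of replacement occurs in a step that the two limits leave unreadable from compound 1 to compound 3 and it offers no size to carry over. Two further changes on a carbonyl carbon, a step that the two limits leave unreadable from compound 1 to compound 2 and a step that the two limits leave unreadable from compound 2 to compound 3, are no more informative. Within the data shown here, no measured step therefore supplies a size or a direction, and no change beyond the scatter is expected in this assay for this replacement.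

The estimated outcome is a step that the limit leaves unreadable from compound 3 to compound 4 and another limit is the likeliest report. For compound 4 the estimated value is 14000 nM with an expected range from 6000 nM to 30000 nM.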

Compound 4, half-maximal effective concentration: > 11100 nM
Compound 4: a limit, no number; the forecaster's own chance of this, stated with the estimate: 75%; the middle value does not contradict the limit.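

In this assay compound 4 reads > 11100 nM as a limit and not a number. Among these compounds, no step among compound 1, compound 2, compound 3 and compound 4 can be read, since all four rest on the same limit: the limit of > 11100 nM in this assay, at which 4 of the 4 values shown sit.

The compounds shown leave open how these four rank against one another and what concentration any of them would need for the effect.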